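This account rests on a few compounds, and the source may have more. Where it says the series, first, only, none or still open, it means among the compounds named here.

Measured so far:
compound 1 `O=C(CCCCCCc1ccccc1)c1ncc(-c2ccc(O)cc2)o1`: 140 nM
compound 2 `O=C(CCCCCCc1ccccc1)c1ncc(-c2nnn[nH]2)o1`: 63 nM
compound 3 `CN1CCN(C(=O)c2cnc(C(=O)CCCCCCc3ccccc3)o2)CC1`: 80 nM

In an assay (Rattus norvegicus) for inhibition of Fatty-acid amide hydrolase 1 (Homo sapiens) (on this read-out lower numbers stand for stronger inhibition and higher numbers for weaker inhibition), compound 3 stands second highest of the three numbers; the two gaps around it are a 1.3-fold higher number from compound 2 to compound 3 (0.10 log units; within the scatter) and a 1.8-fold lower number from compound 1 to compound 3 (0.24 log units; within the scatter). Compound 4 `O=C(CCCCCCc1ccccc1)c1ncc(Cl)o1` differs from compound 3 by chloro in place of (4-methylpiperazin-1-yl)carbonyl on an aromatic carbon. Going by the values given here, no measured step swaps the group at this position for a single atom. Among the compounds with values here, the steps that bear on it are a 2.2-fold lower number from compound 1 to compound 2 (0.35 log units; beyond the scatter), a 1.8-fold lower number from compound 1 to compound 3 (0.24 log units; within the scatter) and a 1.3-fold higher number from compound 2 to compound 3 (0.10 log units; within the scatter), all small, showing three quite different groups at this position giving close numbers. The step of a 1.9-fold higher number from compound 3 to compound 4 (0.27 log units; within the scatter) is therefore expected to be small as well, with the larger uncertainty on the weaker side. In this assay compound 4 is estimated at 150 nM, range 40 nM to 600 nM.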

Compound 4, inhibition constant: 5 nM
Compound 4: middle estimate off by 30-fold (1.48 log units), on the high side, and the stated range ends above it.
By their numbers in this assay, from the lowest: compound 4; then compounds 2, 3 and 1 (each within the scatter of the next, the first and the last beyond it).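

In this assay this position proves sensitive to its substituent: a single chlorine atom gives a 16-fold lower number from compound 3 to compound 4 (1.20 log units; beyond the scatter), a 13-fold lower number from compound 2 to compound 4 (1.10 log units; beyond the scatter) and a 28-fold lower number from compound 1 to compound 4 (1.45 log units; beyond the scatter), while the three larger groups had differed far less among themselves. The large groups therefore did not show what this position can give. Nothing shown explains this change. On these data alone, it stays open whether the gain is specific to chloro or extends to other compact groups; bromo, methyl or plain hydrogen on this carbon would separate these readings.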